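A few compounds are considered here, and "the series" means these few. Any claim that something is new, unique, unknown or untested is made for them only; others in the source may bear on it.

Measured so far, in a physicochemical assay for solubility, read by HPLC, with a stated time of 24 h; a higher number here means a more soluble compound, a lower number a less soluble compound:
compound 1, `O=C1O[C@@H](CN2CCC(O)CC2)CN1c1ccc(-n2cc(-c3ccccn3)cn2)c(F)c1`, gives 45900 nM.
compound 2, `CS(=O)(=O)NC[C@H]1CN(c2ccc(-n3cc(-c4ccccn4)cn3)c(F)c2)C(=O)O1`, gives 2300 nM.

Within the data shown here, compound 2 stands lowest of the two numbers; its nearest neighbour is compound 1, reached by the one measured step, a 20-fold lower number from compound 1 to compound 2 (1.30 log units; beyond the scatter). Compound 3, `NC(=O)[C@H]1CN(c2ccc(-n3cc(-c4ccccn4)cn3)c(F)c2)C(=O)O1`, has not yet been measured. Its change from compound 2 is carbamoyl in place of (methanesulfonamido)methyl on a saturated ring carbon. Among the measured compounds shown here, only the step from compound 1 to compound 2 is available to judge by, and it concerns a different exchange at a different place, so it bears on this change only loosely; it does show that swapping the group on the side chain of this core moved the number well beyond the scatter. For compound 3 the expected step in this assay is a 1.2-fold lower number from compound 2 to compound 3 (0.06 log units; within the scatter), with no clear direction favoured. Compound 3 is therefore estimated at 2000 nM, with a range from 500 nM to 8000 nM.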

Compound 3, solubility: 27200 nM
Compound 3: middle estimate off by 14-fold (1.13 log units), on the low side; measured number outside the range, above it.
By their numbers in this assay, from the lowest: compound 2; then compounds 3 and 1 (each within the scatter of the next).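

In this assay, carbamoyl in place of (methanesulfonamido)methyl on the saturated ring carbon next to the ring oxygen gives a 12-fold higher number from compound 2 to compound 3 (1.07 log units; beyond the scatter) and so shows that the low number of compound 2 does not hold for every group at this place. Carbamoyl, which has no ring and 3 heavy atoms, stands level with (4-hydroxypiperidin-1-yl)methyl, at a 1.7-fold lower number from compound 1 to compound 3 (0.23 log units; within the scatter) in the same assay, so a high number here does not require the hydroxypiperidine group. Nothing available accounts for the difference among these groups.

Going by these compounds, whether the low number of compound 2 goes with the methanesulfonamido group or with the chain that carries it stays open, as this exchange alters both at once. On these data alone, how a carboxylic acid, a primary amine or a longer chain ending in carbamoyl on this ring carbon would compare also remains open.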